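The source may hold more compounds than are shown below. What is called first, only, known or untested is meant among the compounds shown, and "the series" means these compounds.

In a functional assay on NCI-H1975 cells (Homo sapiens) for antiproliferative activity (a lower number here means a stronger inhibitor, a higher number a weaker inhibitor), compound 2 (`Cc1c2c(n3c1CCN(C)C[C@@H](C)[C@H](C)Nc1cc-3ccc1C(N)=O)CC(C)(C)CC2=O`) gives 27 nM. That lies within the scatter of both compound 1 (`Cc1c2c(n3c1CCCN[C@@H](C)[C@H](C)Nc1cc-3ccc1C(N)=O)CC(C)(C)CC2=O`), at 20 nM, and compound 3 (`COCCC(=O)N1CCCc2c(C)c3c(n2-c2ccc(C(N)=O)c(c2)N[C@@H](C)[C@@H]1C)CC(C)(C)CC3=O`), at 37 nM. Compound 4 (`Cc1c2c(n3c1CCN(C(=O)C1(N)CCCC1)C[C@@H](C)[C@H](C)Nc1cc-3ccc1C(N)=O)CC(C)(C)CC2=O`) differs from compound 2 by a single change: a group of 8 heavy atoms (6 carbon, 1 nitrogen, 1 oxygen; one five-membered non-aromatic ring of carbon only) in place of one carbon atom, on an amine nitrogen in a ring. Among the compounds with values here, one measured step bears on this, also a substitution on an amine nitrogen in a ring, though it replaces hydrogen rather than methyl and brings in a different group. That step, a 1.9-fold higher number from compound 1 to compound 3 (0.27 log units; within the scatter), stays within the scatter, so no step beyond the scatter is expected in this assay. The expected change is a 1.2-fold higher number from compound 2 to compound 4 (0.07 log units; within the scatter). Compound 4 is estimated at 32 nM, with an expected range of 12 nM to 85 nM.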

Compound 4, half-maximal inhibitory concentration: 26 nM
Compound 4: the middle estimate sits 1.2-fold (0.09 log units) above what was measured; the range from low to high includes it.
By their numbers in this assay, from the lowest: compounds 1, 4, 2 and 3 (each within the scatter of the next).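

In this assay, putting the group of 8 heavy atoms, with its five-membered non-aromatic ring of carbon only, in place of methyl on this amine nitrogen in a ring gives a 1.0-fold lower number from compound 2 to compound 4 (0.02 log units; within the scatter). The earlier step on such a nitrogen started from hydrogen, whereas this one shows that a much larger group, carrying a hydrogen-bond donor, can replace methyl here and leave the number within the scatter. Nothing given here explains this result. Going by these compounds, it remains open whether a carboxylic acid or a longer chain on this nitrogen would also stay within the scatter. On these data alone, the part played by the amine inside the entering group is also open.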